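Swapping a nitrile for fluorine on the enone chain

The source may report more compounds than this note shows. Statements on the series, on what has been measured and on what is new or still open speak of the compounds shown alone.

Of the compounds shown here, three that share one core have been tested in an ADME assay on K562 cells (Homo sapiens) for cytotoxicity, read by MTT assay, with a stated time of 5 days; on this read-out lower numbers stand for stronger inhibition and higher numbers for weaker inhibition. Compound 1, `COc1ccc(/C=C(\C#N)C(=O)c2cc(OC)c(OC)c(OC)c2)cc1O[Si](C)(C)C(C)(C)C`, gives only the limit > 10000 nM, which marks the edge of what this assay can report rather than a number. Compound 2, `COc1ccc(/C=C(\C#N)C(=O)c2cc(OC)c(OC)c(OC)c2)c(F)c1`, likewise reaches only the limit > 10000 nM. Compound 3, `COc1ccc(/C=C(\C#N)C(=O)c2cc(OC)c(OC)c(OC)c2)cc1F`, also stops at the limit > 10000 nM. Because all three sit at the limit of > 10000 nM in this assay, at which 3 of the 3 values shown sit, the steps a step that the two limits leave unreadable from compound 1 to compound 3 and a step that the two limits leave unreadable from compound 2 to compound 3 cannot be read in size or direction, and compound 3 cannot be placed relative to the other two.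

Compound 4, `COc1ccc(/C=C(\F)C(=O)c2cc(OC)c(OC)c(OC)c2)cc1F`, differs from compound 3 by fluoro in place of cyano on a double-bonded chain carbon bound to a carbonyl carbon and a double-bonded chain carbon. Among the measured compounds shown here, no measured step touches this part of the molecule, so the measured steps give no direction for this assay. The reasonable expectation is that compound 4 behaves like compound 3, with a step that the limit leaves unreadable from compound 3 to compound 4. Compound 4 is therefore estimated at 20000 nM, within a range from 5000 nM to 80000 nM, most likely reported again as a limit.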

Compound 4, half-maximal inhibitory concentration: 770 nM
For compound 4 the middle estimate is 26-fold (1.41 log units) above the measured one, outside the stated range (below it).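

In this assay, the group on the double-bonded chain carbon bound to a carbonyl carbon and a double-bonded chain carbon proves to matter: fluoro in place of cyano gives an at least 12-fold lower number from compound 3 to compound 4 (1.11 log units; beyond the scatter). Among the compounds shown here, this is the first change with a step that can be read, and its true size may be larger than the printed figure, as compound 3 has only a limit and no exact number. Compound 4 is the only compound shown that falls inside the measurable range, while the others stay at the edge of the assay: the limit of > 10000 nM in this assay, at which 3 of the 4 values shown sit.

From the compounds shown here alone, with only nitrile and fluoro seen on this carbon, it remains open whether a chlorine atom, a methyl group or a hydrogen atom there would give a similar value. Going by these compounds, it also remains open whether the same swap would lower the number in compound 1 or compound 2.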